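Ester to Primary Amide in a Ramos Antiproliferative Series

The source may report more compounds than this note shows. Statements on the series, on what has been measured and on what is new or still open speak of the compounds shown alone.

Compound 1 `CCOC(=O)c1sc(-c2cccc(NC(=O)c3ccc(C(F)(F)F)cc3)c2)nc1Nc1ccc(N2CCN(C)CC2)cc1` has the lower of the two numbers in a functional assay on Ramos cells (Homo sapiens) for antiproliferative activity, read by CCK-8 assay, with a stated time of 72 h, tested at 40 uM (a higher number here means more inhibition at the concentration tested (going by the name of the read-out), a lower number less inhibition), giving 18.4%, while compound 2 `CCOC(=O)c1sc(-c2cccc(NC(=O)c3ccc(F)c(Cl)c3)c2)nc1Nc1ccc(N2CCN(C)CC2)cc1` in this assay gives 72.5%; that step reads a number 54.1 percentage points higher from compound 1 to compound 2 (beyond the scatter). Compound 3 `CN1CCN(c2ccc(Nc3nc(-c4cccc(NC(=O)c5ccc(C(F)(F)F)cc5)c4)sc3C(N)=O)cc2)CC1` differs from compound 1 by amino in place of ethoxy on a carbonyl carbon, which cut one bond further out reads ethoxycarbonyl to carbamoyl. Within the data shown here, no measured step touches this position; the single known step concerns a different group, so its size does not transfer. The expected step is therefore small, a number 6.6 percentage points higher from compound 1 to compound 3 (within the scatter). Compound 3 is estimated at 25%, with a range from 5% to 55%.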

Compound 3, a percentage reported as inhibition, at one concentration (the size of the read-out at that concentration, not a potency): 97.8%
Compound 3: middle estimate off by 72.8 percentage points, on the low side; measured number above the stated range.
By their numbers in this assay, from the lowest: compound 1; then compound 2; then compound 3.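

In this assay, amino in place of ethoxy on a carbonyl carbon gives a number 79.4 percentage points higher from compound 1 to compound 3 (beyond the scatter). This shows that the ethoxycarbonyl position, which the earlier pair left unchanged, is itself able to carry a large step while the 4-(trifluoromethyl)phenyl group stays in place. Nothing available explains why this change has such an effect.

Going by these compounds, it remains open whether methylamino or a carboxylic acid at this carbonyl carbon would behave like amino. On these data alone, it also remains open whether the same change would give a similar step with the 3-chloro-4-fluorophenyl group of compound 2.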